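A methyl-to-fluoro swap at the assay's limit

A few compounds are considered here, and "the series" means these few. Any claim that something is new, unique, unknown or untested is made for them only; others in the source may bear on it.

Values so far in a toxicity assay on Huh-7 cells (Homo sapiens) for cytotoxicity, read by CCK-8 assay, with a stated time of 24 h (a higher number here means that more compound is tolerated, a lower number that less compound is tolerated), are these
- compound 1 `Cc1ccc(-c2c(O)c(O)c(O)c3c(=O)cc(-c4ccccc4)oc23)cc1` gives > 100000 nM
- compound 2 `Oc1c(O)c(O)c2c(=S)cc(-c3ccccc3)oc2c1-c1ccc(F)cc1` gives > 100000 nM
- compound 3 `Oc1cc2oc(-c3ccccc3)cc(=S)c2c(O)c1O` gives > 100000 nM

All three values are limits, not numbers (the limit of > 100000 nM in this assay, at which 3 of the 3 values shown sit). In this assay compound 1 stands at > 100000 nM as a limit. Compound 4 `O=c1cc(-c2ccccc2)oc2c(-c3ccc(F)cc3)c(O)c(O)c(O)c12` differs from it by the change of 4-methylphenyl to 4-fluorophenyl, fluoro in place of methyl on an aromatic carbon, para to a large group (fluoro in place of methyl on an aromatic carbon). Among the compounds with values here, the only measured step (a step that the two limits leave unreadable from compound 2 to compound 3) offers no size to carry over, though compound 2 already bears the 4-fluorophenyl group. No shift beyond the scatter is therefore expected, and compound 4 may well report only a limit. The expected step is small (a number no higher from compound 1 to compound 4 (the limit leaves the size open)). Compound 4 is estimated at 100000 nM (expected range 50000 nM to 200000 nM).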

Compound 4, half-maximal cytotoxic concentration: > 100000 nM
Compound 4 was reported as a limit (the forecaster's own chance of this, stated with the estimate: 85%); the middle value sits exactly at the limit.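

No step can be read between compound 1 and compound 4, because both values are limits: the limit of > 100000 nM in this assay, at which 4 of the 4 values shown sit.

The compounds shown leave open whether any of them has a measurable half-maximal cytotoxic concentration in this assay, and so whether fluoro and methyl differ there at all.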